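Acylation of the Hydroxyl of Compound 1 with a Benzoyl Group

The compounds below may be only part of what the source reports. "The series", "measured", "known", "first", "only" and "open" are said of these compounds alone.

Compound 1 `C=C1C(=O)[C@@]23C(=O)OC[C@]4(C(=O)CCC(C)(C)[C@H]4C=O)[C@@H]2CC[C@@H]1[C@H]3O` gives the highest number among the three measured compounds in a functional assay on K562 cells (Homo sapiens) for cytotoxicity, read by MTT assay, with a stated time of 72 h (on this read-out higher numbers stand for weaker inhibition and lower numbers for stronger inhibition), at 2180 nM. Its acetyl ester, compound 2 `C=C1C(=O)[C@@]23C(=O)OC[C@]4(C(=O)CCC(C)(C)[C@H]4C=O)[C@@H]2CC[C@@H]1[C@H]3OC(C)=O`, gives 1390 nM, and its propanoyl ester, compound 3 `C=C1C(=O)[C@@]23C(=O)OC[C@]4(C(=O)CCC(C)(C)[C@H]4C=O)[C@@H]2CC[C@@H]1[C@H]3OC(=O)CC`, gives 1310 nM. The steps are small: a 1.6-fold lower number from compound 1 to compound 2 (0.20 log units; within the scatter), a 1.7-fold lower number from compound 1 to compound 3 (0.22 log units; within the scatter), and between the two esters a 1.1-fold lower number from compound 2 to compound 3 (0.03 log units; within the scatter). Compound 4 `C=C1C(=O)[C@@]23C(=O)OC[C@]4(C(=O)CCC(C)(C)[C@H]4C=O)[C@@H]2CC[C@@H]1[C@H]3OC(=O)c1ccc(C(F)(F)F)cc1` differs from compound 1 by (4-(trifluoromethyl)phenyl)carbonyl in place of hydrogen on an oxygen on a saturated carbon. The change sits on an oxygen on a saturated carbon, the same place where acetyl and propanoyl entered, so those two steps bear on it; both were within the scatter and both pointed toward lower numbers. The entering group carries one six-membered aromatic ring of carbon only, which neither measured ester does, and nothing measured here shows how such a group behaves at this place, so the expected step is a 2.0-fold lower number from compound 1 to compound 4 (0.30 log units; within the scatter), toward lower numbers and possibly just beyond the scatter but not assuredly so. Compound 4 is therefore estimated at 1100 nM, with a range from 350 nM to 3500 nM.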

Compound 4, half-maximal inhibitory concentration: 2820 nM
Beside the measured number, compound 4's estimate is 2.6-fold (0.41 log units) below it, and the stated range covers the measured number.
By their numbers in this assay, from the lowest: compounds 3, 2, 1 and 4 (each within the scatter of the next, the first and the last beyond it).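

In this assay, (4-(trifluoromethyl)phenyl)carbonyl on the oxygen on a saturated carbon leaves the number within the scatter of the free hydroxyl, with a 1.3-fold higher number from compound 1 to compound 4 (0.11 log units; within the scatter), so the lean toward lower numbers seen with the two small esters does not carry over to this group. The new information lies among the esters, where the group on the carbonyl carbon now gives steps beyond the scatter, though modest ones: a 2.0-fold higher number from compound 2 to compound 4 (0.31 log units; beyond the scatter) and a 2.2-fold higher number from compound 3 to compound 4 (0.33 log units; beyond the scatter). No measured evidence bears on the reason for these steps.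

The compounds shown leave open whether these steps follow from the aromatic ring or from the trifluoromethyl group, which a plain benzoyl ester would help to separate. On these data alone, how a longer chain such as butanoyl, or an acyl group carrying an amine, behaves on this oxygen also remains open.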